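The compounds below may be only part of what the source reports. "The series", "measured", "known", "first", "only" and "open" are said of these compounds alone.

Working notes on the series. Among the measured compounds shown here, compound 1 `COc1cccc(OC)c1OCCNCCOc1ccccc1OCc1ccc(Cl)cc1` in a functional assay on thoracic aorta for antagonist activity at Alpha-1D adrenergic receptor (Rattus norvegicus) (on this read-out lower numbers stand for lower potency and higher numbers for higher potency (the scale is a negative logarithm)), gives 9.11, the higher of the two numbers so far; compound 2 `COc1cccc(OC)c1OCCNCCOc1ccccc1OCc1cccc(C)c1` gives 8.85, and the step of a number 0.26 log units lower from compound 1 to compound 2 (within the scatter) stays within the scatter. Compound 3 `COc1cccc(OC)c1OCCNCCOc1ccccc1OCc1ccccc1[N+](=O)[O-]` differs from compound 1 by 2-nitrophenyl in place of 4-chlorophenyl on a saturated chain carbon bound to an oxygen on an aromatic ring. For the measured compounds named here, no measured step exchanges the 4-chlorophenyl for a nitrophenyl; the only step at this place, from compound 1 to compound 2, was small. For compound 3 the change in this assay is therefore expected to be a number 0.31 log units lower from compound 1 to compound 3 (beyond the scatter), with an estimated value of 8.8, range 8.2 to 9.4.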

Compound 3, negative logarithm of the antagonist equilibrium constant: 8.95
For compound 3 the middle estimate is 0.15 log units below the measured one; the measured number falls inside the stated range.
By their numbers in this assay, from the lowest: compounds 2, 3 and 1 (each within the scatter of the next).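

In this assay the 2-nitrophenyl group at this place, on a saturated chain carbon bound to an oxygen on an aromatic ring, stays level with both earlier groups, with a number 0.16 log units lower from compound 1 to compound 3 (within the scatter) and a number 0.10 log units higher from compound 2 to compound 3 (within the scatter). A third aryl group, this one with hydrogen-bond acceptors that 4-chlorophenyl lacks, therefore leaves the number within the scatter. Nothing available bears on why this change is tolerated. Still open, going by these compounds, is whether a group other than an aryl ring, such as an amine, a carboxylic acid or a longer alkyl chain, would hold the number here as well.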